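The source may report more compounds than this note shows. Statements on the series, on what has been measured and on what is new or still open speak of the compounds shown alone.

Among the compounds with values here, compound 2 `COc1cc(-c2noc([C@H](C)NC(=O)c3cc(C(F)(F)F)nn3C)n2)ccn1` gives 27 nM in an assay on T-REx-293 cells for inhibition of potassium channel subfamily T member 1 (Homo sapiens), read by patch clamp (on this read-out higher numbers stand for weaker inhibition and lower numbers for stronger inhibition), the lowest of the two numbers so far; compound 1 `Cc1cncc(-c2noc([C@H](C)NC(=O)c3cc(C(F)(F)F)nn3C)n2)c1` gives 1370 nM. Within the data shown here, the one measured step, a 51-fold lower number from compound 1 to compound 2 (1.71 log units; beyond the scatter), exchanged the whole aryl group on the shared core. Compound 3 `CNc1cc(-c2noc([C@H](C)NC(=O)c3cc(C(F)(F)F)nn3C)n2)ccn1` instead keeps that group and carries methylamino in place of methoxy on an aromatic carbon, next to the ring nitrogen. Among the measured compounds shown here, no measured step touches this position, so nothing supports a large shift in either direction; a step within the usual scatter, a 1.5-fold higher number from compound 2 to compound 3 (0.17 log units; within the scatter), is expected. Compound 3 is estimated at 40 nM, with a range from 10 nM to 160 nM.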

Compound 3, half-maximal inhibitory concentration: 195 nM
For compound 3 the middle estimate is 4.9-fold (0.69 log units) below the measured one; measured number outside the range, above it.
By their numbers in this assay, from the lowest: compound 2; then compound 3; then compound 1.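

At the aromatic carbon next to the ring nitrogen, methylamino in place of methoxy, which adds one hydrogen-bond donor, is not a neutral exchange in this assay (a 7.2-fold higher number from compound 2 to compound 3 (0.86 log units; beyond the scatter)). The 2-(methylamino)pyridin-4-yl group still stands apart from 5-methylpyridin-3-yl (a 7.0-fold lower number from compound 1 to compound 3 (0.85 log units; beyond the scatter)), so this aryl change keeps part of its effect with methylamino on that carbon. Nothing available accounts for the loss from methoxy to methylamino.

The compounds shown leave open whether the ring-bound nitrogen or its hydrogen governs the step. Dimethylamino or a free amine on that carbon would separate these two.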